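The source may hold more compounds than are shown below. What is called first, only, known or untested is meant among the compounds shown, and "the series" means these compounds.

The measured compounds:
Compound 1, `CCCCC/C=C\C/C=C\CCCCCCCc1cc(=O)c2c(O)c(C)c(OCOC)c(C)c2o1`, reaches only a limit in a functional assay on MCF7 cells (Homo sapiens) for antiproliferative activity, read by MTT assay (on this read-out higher numbers stand for weaker inhibition and lower numbers for stronger inhibition), namely > 84100 nM.
Compound 2, `CC/C=C\C/C=C\C/C=C\CCCCCCCc1cc(=O)c2c(O)c(C)c(OCOC)c(C)c2o1`, reaches only a limit in this assay, namely > 84100 nM.
Compound 3, `CCCCC/C=C\C/C=C\CCCCCCCc1cc(=O)c2c(O)c(C)c(OCOC)cc2o1`, reaches only a limit in this assay, namely > 67200 nM.

All three compounds share one core and differ in two places. From compound 1 to compound 2 the change is but-1-en-1-yl in place of butyl on a saturated chain carbon bound to a double-bonded chain carbon, and the step it made is a step that the two limits leave unreadable from compound 1 to compound 2; the step cannot be read since both values are limits, as the limit of > 84100 nM in this assay, at which 2 of the 3 values shown sit, shows. From compound 1 to compound 3 the change is hydrogen in place of methyl on an aromatic carbon, and the step is a step that the two limits leave unreadable from compound 1 to compound 3; here too the two limits, the limit of > 67200 nM in this assay, at which 1 of the 3 values shown sits, and (the limit of > 84100 nM in this assay, at which 2 of the 3 values shown sit), leave the size hidden.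

Compound 4, `CC/C=C\C/C=C\C/C=C\CCCCCCCc1cc(=O)c2c(O)c(C)c(OCOC)cc2o1`, has not yet been measured in this assay. Within the data shown here, it differs from compound 3 by but-1-en-1-yl in place of butyl on a saturated chain carbon bound to a double-bonded chain carbon, which is the same change as the one from compound 1 to compound 2, made on the core of compound 3. That earlier change left compound 2 at a limit just as compound 1 was, so no shift of readable size is known for it. The step from compound 3 to compound 4 is therefore expected to be a step that the limit leaves unreadable from compound 3 to compound 4, an expectation resting on compound 3 at > 67200 nM and on the pair compound 1 and compound 2 both sitting at limits. Compound 4 is expected to give 90000 nM, most likely again as a limit, within a range from 50000 nM to 200000 nM.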

Compound 4, half-maximal inhibitory concentration: 17500 nM
Compound 4: middle estimate off by 5.1-fold (0.71 log units), on the high side; the whole stated range lies above it.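

In this assay, on these data alone, but-1-en-1-yl in place of butyl on a saturated chain carbon bound to a double-bonded chain carbon gives an at least 3.8-fold lower number from compound 3 to compound 4 (0.58 log units; beyond the scatter), so on this core the change has a real effect, whose full size stays open as compound 3 sits at a limit. On the core of compound 1 the same change yields no readable step, and this holds for every step between compounds that both sit at a limit, since compound 1 and compound 2 share one limit: the limit of > 84100 nM in this assay, at which 2 of the 4 values shown sit. Among these compounds, the change therefore cannot be said to carry over from one core to the other, nor to fail to, and the result with hydrogen in place of methyl on an aromatic carbon, an at least 4.8-fold lower number from compound 2 to compound 4 (0.68 log units; beyond the scatter), shows only that compound 4 stands apart from compound 2, which suggests that the two changes may act together but does not establish it.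

What the compounds shown leave open is how far the number would move on the core of compound 1 if its values could be read. They also leave open whether a longer chain, or an amine or a carboxylic acid in place of these chains, would keep or lose the effect seen with compound 4.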